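The compounds below may be only part of what the source reports. "The series", "measured", "known", "first", "only" and "open" are said of these compounds alone.

Measured so far in a functional assay on a cell-free system (plasma, Homo sapiens) for inhibition, with Plasma (Rattus norvegicus) as the target; on this read-out lower numbers stand for stronger inhibition and higher numbers for weaker inhibition:
- compound 1 `O=c1cc(N2CCNCC2)oc2ccccc12` gives 240000 nM
- compound 2 `Cc1c(OCc2ccccc2)ccc2c(N3CCNCC3)cc(=O)oc12` gives 1100 nM

Of these two numbers, compound 2 holds the lower, and the gap to compound 1 lies beyond the scatter. For the measured compounds named here, no step confined to one place connects measured compounds, so the size of the next step cannot be read from the series.

Compound 3 `CCOCOc1ccc2c(N3CCNCC3)cc(=O)oc2c1C` is not yet measured. It carries ethoxy in place of phenyl on a saturated chain carbon bound to an oxygen on an aromatic ring and is otherwise the same as compound 2.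

A moderate rise in the number is expected in this assay, meaning weaker inhibition, and the estimated change is a 3.2-fold higher number from compound 2 to compound 3 (0.50 log units; beyond the scatter) as a tentative figure. A result within the scatter of compound 2 would not be surprising. The estimate for compound 3 is 3500 nM with an expected range from 1000 nM to 15000 nM as the working figures.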

Compound 3, half-maximal inhibitory concentration: 1900 nM
Estimate against measurement, compound 3: 1.8-fold (0.27 log units) above; the measured number falls inside the stated range.
By their numbers in this assay, from the lowest: compounds 2 and 3 (each within the scatter of the next); then compound 1.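

In this assay, replacing phenyl with ethoxy on a saturated chain carbon bound to an oxygen on an aromatic ring gives a 1.7-fold higher number from compound 2 to compound 3 (0.24 log units; within the scatter), the first read of a single change in this series. For this pair, benzyloxy and ethoxymethoxy cannot be told apart, so the six-membered aromatic ring of carbon only is not required to keep the number at this level, and 3 heavy atoms serve here as well as 6. No evidence at hand bears on this result.

On these data alone, it remains open whether an amine, a carboxylic acid or a longer chain at this place would also leave the number within the scatter. Also open, as far as these compounds go, is whether a plain methoxy or hydroxyl in place of ethoxymethoxy would hold it there.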